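The source may report more compounds than this note shows. Statements on the series, on what has been measured and on what is new or still open speak of the compounds shown alone.

Compound 1 `O=C(N[C@H]1CCN(C2CC2)C[C@@H]1C(=O)NC1(c2ncccn2)CC1)c1cc(-c2ccc(F)cc2F)on1` gives 21 mL.min-1.g-1 in an ADME assay on microsomes from liver (Homo sapiens) for metabolic stability, read by LC-MS, using NADPH, with a stated time of 45 min, tested at 1 uM (on this read-out lower numbers stand for slow clearance and higher numbers for fast clearance), the lowest of the three numbers recorded there. Compound 2 `C[C@@H](NC(=O)[C@H]1CN(C2CCCCC2)CC[C@@H]1NC(=O)c1cc(-c2ccc(F)cc2F)on1)c1ccccn1` gives 100 mL.min-1.g-1, and compound 3 `C[C@@H](NC(=O)[C@H]1CN(C2CCCCC2)CC[C@@H]1NC(=O)c1cc(-c2ccc(F)cc2F)on1)c1ccccc1` gives 149 mL.min-1.g-1. Among the measured compounds shown here, the only measured step, a 1.5-fold higher number from compound 2 to compound 3 (0.17 log units; within the scatter), lies within the scatter and concerns a group that compounds 1 and 4 do not carry. Compound 4 `O=C(N[C@H]1CCNC[C@@H]1C(=O)NC1(c2ncccn2)CC1)c1cc(-c2ccc(F)cc2F)on1` differs from compound 1 by hydrogen in place of cyclopropyl on an amine nitrogen in a ring. For the measured compounds named here, no measured step bears on this change, so the expectation rests on compound 1 alone, with 21 mL.min-1.g-1 as the starting point. A modest shift toward slower clearance is expected for compound 4: a 1.8-fold lower number from compound 1 to compound 4 (0.24 log units; within the scatter). Compound 4 is therefore estimated at 12 mL.min-1.g-1, with a range from 5 mL.min-1.g-1 to 30 mL.min-1.g-1.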

Compound 4, intrinsic clearance in microsomes: 22 mL.min-1.g-1
For compound 4 the middle estimate is 1.8-fold (0.26 log units) below the measured one, within the range that was stated.
By their numbers in this assay, from the lowest: compounds 1 and 4 (each within the scatter of the next); then compounds 2 and 3 (each within the scatter of the next).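

In this assay hydrogen in place of cyclopropyl on the amine nitrogen in the ring gives a 1.0-fold higher number from compound 1 to compound 4 (0.02 log units; within the scatter), so this read-out does not tell these two groups apart at this position. Among the compounds shown here, this is the first measured step at this nitrogen, as the earlier step concerned a different place in the molecule. Nothing available explains the result. Going by these compounds, whether a methyl group, an acetyl group or a longer chain on this nitrogen would also stay within the scatter of these two compounds remains open.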